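Swapping Nitro for Methoxy on an Aromatic Ester

The compounds below may be only part of what the source reports. "The series", "measured", "known", "first", "only" and "open" are said of these compounds alone.

Two esters built on the same core have been measured. Compound 1 `CC1=CC[C@H](C(C)C)c2cc(C)c(OC(=O)c3ccc([N+](=O)[O-])cc3)cc21` carries a nitro group on its aromatic ring, while compound 2 `COc1cccc(C(=O)Oc2cc3c(C)ccc(C(C)C)c3cc2C)c1` carries a methoxy group on a different aromatic carbon of that ring. In a functional assay on SK-LU-1 cells (Homo sapiens) for antiproliferative activity, read by sulforhodamine B assay, with a stated time of 48 h, tested at 50 uM (on this read-out higher numbers stand for more inhibition at the one concentration tested (going by the name of the read-out) and lower numbers for less inhibition), compound 1 gives 47.5%, the higher of the two numbers; compound 2 gives 30.6%, a difference beyond the usual scatter of this kind of measurement.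

Compound 3 `COc1ccc(C(=O)Oc2cc3c(cc2C)[C@@H](C(C)C)CC=C3C)cc1` has not yet been tested. It differs from compound 1 in one place: methoxy in place of nitro on an aromatic carbon. Within the data shown here, no measured pair shows this exact change, so the size of its effect is not yet known. Compound 2 already shows that a methoxy ester on this core can give a lower number than compound 1, so the expectation is a moderate drop, estimated as a number 14.5 percentage points lower from compound 1 to compound 3 (beyond the scatter) in this assay. Among the measured compounds shown here, the estimated inhibition for compound 3 in this assay is 33%, with a range from 15% to 50%, the wide span reflecting that only two compounds are available.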

Compound 3, a percentage reported as inhibition, at one concentration (the size of the read-out at that concentration, not a potency): 18.6%
Estimate against measurement, compound 3: 14.4 percentage points above; low and high end bracket the measured number.
By their numbers in this assay, from the lowest: compound 3; then compound 2; then compound 1.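

In this assay, exchanging the 4-nitrophenyl of the ester for 4-methoxyphenyl, with the rest of the molecule left as it is, gives a number 28.9 percentage points lower from compound 1 to compound 3 (beyond the scatter). Among these compounds, this is the first reading in which a change in the number can be tied to a single place, since compound 1 and compound 2 differ in more than one place and could not show this. It shows that the group on this aromatic carbon, para to a large group, matters for inhibition at the one concentration tested, although the data shown offer no measured explanation for the change.

Going by these compounds, with only nitro and methoxy read at this carbon, two groups cannot establish a trend, so it stays open where an amine, a carboxylic acid or a longer chain such as butoxy would fall in this cell assay. Also open, on these data alone, is whether the same exchange would give a step of similar size at another carbon of the ring, and whether the step would hold at other concentrations, as a single-concentration percentage is not a measure of potency.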